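Benzyl for Phenyl on a Saturated Ring Carbon

A few compounds are considered here, and "the series" means these few. Any claim that something is new, unique, unknown or untested is made for them only; others in the source may bear on it.

Compound 1 `Nc1ccccc1NC(=O)c1ccc(CNC2=N[C@@H](Cc3ccccc3)CS2)cc1`: > 20000 nM, a limit
Compound 2 `Nc1ccccc1NC(=O)c1ccc(CNC2=NC(=O)C(c3ccccc3)N2)cc1`: > 20000 nM, a limit
Compound 3 `Nc1ccccc1NC(=O)c1ccc(CNC2=NC(=O)C(Cc3ccccc3)N2)cc1`: not yet measured

In an assay on isolated protein for inhibition of protein deacetylase HDAC6 (Homo sapiens), read by fluorescence, with stated times of 3 h and 60 min (a higher number here means a weaker inhibitor, a lower number a stronger inhibitor), compound 1 gives only a limit, > 20000 nM. Compound 2 likewise gives only a limit in this assay, > 20000 nM. Compound 2 thus stands at the point that both measured values share, as the limit of > 20000 nM in this assay, at which 2 of the 2 values shown sit, records. Compound 3 differs from compound 2 by benzyl in place of phenyl on a saturated ring carbon. Among the compounds with values here, no measured step covers this change, and both measured compounds sit at the limit. Compound 3 is expected to remain at that limit as well, so the estimated step that the limit leaves unreadable from compound 2 to compound 3 is none beyond the scatter. The estimate for compound 3 is 30000 nM, with a range from 10000 nM to 100000 nM.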

Compound 3, half-maximal inhibitory concentration: > 20000 nM
Compound 3 ended at the assay's limit; the forecaster's own chance of this, stated with the estimate: 85%; the middle value is on the limit's open side.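

In this assay compound 3 gives > 20000 nM, a limit. Within the data shown here, compound 2 also stands at a limit, so no step between compound 2 and compound 3 can be read. The compounds shown leave open whether benzyl and phenyl on the saturated ring carbon differ at all.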